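The compounds below may be only part of what the source reports. "The series", "measured", "known", "first", "only" and "open" are said of these compounds alone.

Of the compounds shown here, three built on one shared core have been tested in an ADME assay on a cell-free system (plasma, Homo sapiens) for protein binding, using equilibrium dialysis, with a stated time of 5 h, tested at 10 uM; a higher number here means a larger unbound share of the compound, a lower number a smaller unbound share. Compound 2 `Cc1cn([C@H]2CCCN([C@H](CC(C)C)c3ccc(C(=O)O)c(Oc4cccc(Cl)c4)c3F)C2)c(=O)[nH]c1=O` gives 0.013 in this assay. Compound 3 `Cc1cn([C@H]2CCCN([C@@H](CC(C)C)c3ccc(C(=O)O)c(Oc4cccc(Cl)c4)c3F)C2)c(=O)[nH]c1=O` gives 0.007 in this assay, and the step between them, a 1.9-fold lower number from compound 2 to compound 3 (0.27 log units; within the scatter), rests only on (the fact that compounds 2 and 3 differ only in the configuration as drawn). Compound 1 `CC[C@H](c1ccc(C(=O)O)c(Oc2cccc(Cl)c2)c1F)N1CCC[C@H](n2cc(C)c(=O)[nH]c2=O)C1` sits at the limit of < 0.01 in this assay, at which 1 of the 3 values shown sits, so its value of < 0.01 is a limit of the method and not a number. Moving from compound 1 to compound 2, where isopropyl replaces methyl, produces an at least 1.3-fold higher number from compound 1 to compound 2 (0.11 log units; that floor lies within the scatter).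

Compound 4 `CCC[C@H](c1ccc(C(=O)O)c(Oc2cccc(Cl)c2)c1F)N1CCC[C@H](n2cc(C)c(=O)[nH]c2=O)C1` has not been measured. Against compound 2 its change is hydrogen in place of methyl on a saturated chain carbon bound to two saturated chain carbons, so compound 4 carries a chain shorter than compound 2 but longer than compound 1. Among the compounds with values here, the one measured step that bears on it, an at least 1.3-fold higher number from compound 1 to compound 2 (0.11 log units; that floor lies within the scatter), was small, and the change in compound 4 is smaller still. Compound 4 is therefore expected to show a 1.3-fold lower number from compound 2 to compound 4 (0.11 log units; within the scatter), a shift not beyond the usual scatter. Compound 4 is estimated at 0.01, with a likely range from 0.005 to 0.02.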

Compound 4, unbound fraction: < 0.01
Compound 4: no number, only a limit; the forecaster's own chance of this, stated with the estimate: 45%; the middle value sits exactly at the limit.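

In this assay, from the compounds shown here alone, hydrogen in place of methyl on a saturated chain carbon bound to two saturated chain carbons, which turns isobutyl into propyl, gives an at least 1.3-fold lower number from compound 2 to compound 4 (0.11 log units; that floor lies within the scatter), and this floor is all that can be read of the step, so its full size stays unknown. The value of compound 4 is a limit and not a number, and this reading is now shared by two compounds: the limit of < 0.01 in this assay, at which 2 of the 4 values shown sit.

Compound 1 and compound 4 both stand as limits, and the step between them cannot be read, so the data do not tell whether this change of chain matters at that end of the series.

Open, going by these compounds, is whether a longer chain, a hydroxyl or an amine on this saturated chain carbon would give a readable number. Also open, on these data alone, is the true unbound share of compound 4.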